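This account rests on a few compounds, and the source may have more. Where it says the series, first, only, none or still open, it means among the compounds named here.

Working notes on the sulfonyl series. In a toxicity assay on Vero cells (Chlorocebus sabaeus) for cytotoxicity, read by MTT assay (on this read-out higher numbers stand for weaker inhibition and lower numbers for stronger inhibition), compound 2 `COC(=O)NC(=O)c1ccsc1NC(=O)c1ccc(S(=O)(=O)N2CCCC2)cc1` gives 39.5 ug/mL, the higher of the two numbers available, and compound 1 `COC(=O)NC(=O)c1ccsc1NC(=O)c1ccc(S(=O)(=O)N2CCC2)cc1` gives 17.5 ug/mL. Compound 3 `COC(=O)NC(=O)c1ccsc1NC(=O)c1ccc(S(=O)(=O)N2CCC(c3ccccc3)CC2)cc1` adds no number to the comparison, its entry reading "nd" (no result reported).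

Compound 4 `COC(=O)NC(=O)c1ccsc1NC(=O)c1ccc(S(=O)(=O)NC2CCOCC2)cc1` has not yet been measured. It differs from compound 2 at one place, with (oxan-4-yl)amino in place of pyrrolidin-1-yl on a sulfonyl sulfur.

For the measured compounds named here, only one measured step bears on this change: a 2.3-fold higher number from compound 1 to compound 2 (0.35 log units; beyond the scatter). That step is modest and lies beyond the scatter. It also touches the same sulfonyl sulfur, but it exchanges one ring for another and does not bring in the hydrogen-bond donor and acceptor counted for the new group. It therefore offers only a rough guide to size and no reliable direction for the present change. With a single step to draw on, no shift beyond the scatter is expected in this assay, and the range must stay wide on both sides.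

The expected step is a 1.0-fold higher number from compound 2 to compound 4 (0.01 log units; within the scatter). For compound 4 the estimated value is 40 ug/mL, with an expected range from 15 ug/mL to 110 ug/mL.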

Compound 4, half-maximal inhibitory concentration: 35.7 ug/mL
Beside the measured number, compound 4's estimate is 1.1-fold (0.05 log units) above it, within the range that was stated.
By their numbers in this assay, from the lowest: compound 1; then compounds 4 and 2 (each within the scatter of the next).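

In this assay the exchange on the sulfonyl sulfur gives a 1.1-fold lower number from compound 2 to compound 4 (0.04 log units; within the scatter), so the (oxan-4-yl)amino group, with its six-membered ring and its hydrogen-bond donor and acceptor, reads the same as pyrrolidin-1-yl within the scatter. Set against azetidin-1-yl, the new group gives a 2.0-fold higher number from compound 1 to compound 4 (0.31 log units; beyond the scatter), which sits with the earlier 2.3-fold higher number from compound 1 to compound 2 (0.35 log units; beyond the scatter) and leaves compound 1 apart from compound 2 and compound 4, which cannot be told apart. No measurement shown here accounts for this outcome.

On these data alone, whether a morpholin-4-yl group, a piperazin-1-yl group with its free amine, or an open-chain dimethylamino group on the sulfonyl sulfur would stay level with compound 2 and compound 4 or fall toward compound 1 remains open. A carboxylic acid carried on the ring of the (oxan-4-yl)amino group is equally untested by these numbers, and the compounds shown do not say whether the separation of compound 1 belongs to the azetidin-1-yl group alone.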